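The compounds below may be only part of what the source reports. "The series", "measured", "known", "first", "only" and "open" are said of these compounds alone.

Series notes. Compound 1 `CCNc1nc(N)c2nc(O)n(Cc3ccccc3)c2n1` is the reference point here. Going by the values given here, in a functional assay (spleen, spleen) for activation, with Mus musculus as the target (on this read-out higher numbers stand for an effect only at larger amounts of compound and lower numbers for an effect already at smaller amounts), compound 1 gives 1 uM, the highest of the three numbers measured so far. Compound 2 `CCCCCNc1nc(N)c2nc(O)n(Cc3ccccc3)c2n1` gives 0.1 uM in this assay, and compound 3 `CCCCOc1nc(N)c2[nH]c(=O)n(Cc3ccccc3)c2n1` gives 0.001 uM, the lowest number of the set. Among the compounds with values here, the only one-place step measured within the set, a 10-fold lower number from compound 1 to compound 2 (1.00 log units; beyond the scatter), goes with propyl in place of hydrogen on a saturated chain carbon, two bonds along the chain from a nitrogen on an aromatic ring: a longer chain, a lower number.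

Compound 4 `CCc1nc(N)c2nc(O)n(Cc3ccccc3)c2n1` is next. It differs from compound 1 as follows: ethyl in place of ethylamino on an aromatic carbon. The nitrogen joining the chain to the core is lost and the chain is shorter. Within the data shown here, no measured step covers loss of that nitrogen; the step from compound 1 to compound 2 concerns chain length alone and points the other way, since compound 4 carries fewer chain atoms than compound 1. Compound 3 shows that oxygen in place of that nitrogen is compatible with a very low number, but says nothing about no heteroatom at all. Among the measured compounds shown here, for compound 4 the estimated step is a 3.0-fold higher number from compound 1 to compound 4 (0.48 log units; beyond the scatter), upward, resting on the reversed direction of the one measured step and on the absence of any measured analogue lacking a linking heteroatom. Compound 4 is estimated at 3 uM in this assay, within 0.5 uM to 30 uM.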

Compound 4, minimum effective concentration: 1 uM
Beside the measured number, compound 4's estimate is 3.0-fold (0.48 log units) above it, and the stated range covers the measured number.
By their numbers in this assay, from the lowest: compound 3; then compound 2; then compounds 1 and 4 (each within the scatter of the next).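

In this assay, going by these compounds alone, the exchange of ethylamino for ethyl on this aromatic carbon, between two ring nitrogen atoms, gives no change at the digits printed from compound 1 to compound 4 (within the scatter); at the level of compound 1, the read-out therefore does not depend on the linking nitrogen or on the hydrogen-bond donor and acceptor that leave with ethylamino, which the earlier compounds, all with a heteroatom at this position, could not show. The same position gives a 10-fold higher number from compound 2 to compound 4 (1.00 log units; beyond the scatter) when ethyl replaces pentylamino, so the lower number of compound 2 is not retained by ethyl, although this step changes the chain and removes the nitrogen at once. No available measurement on the compounds bears on why the nitrogen can be lost without a change in the number.

As far as these compounds go, whether a pentyl chain joined directly to this aromatic carbon would keep the number of compound 2 remains open, and this is the comparison that would separate chain length from the linking nitrogen at the longer end. Also open, from the compounds shown here alone, is how butylamino compares with the butoxy group of compound 3, which would isolate oxygen against nitrogen at a single chain length.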